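The source may report more compounds than this note shows. Statements on the series, on what has been measured and on what is new or still open speak of the compounds shown alone.

Measured so far in an ADME assay on MT4 cells (Homo sapiens) for cytotoxicity, read by MTT assay; on this read-out higher numbers stand for lower toxicity in this test and lower numbers for higher toxicity in this test:
Compound 1 `O=C(CSc1nc(Cc2c(F)cccc2F)cc(=O)[nH]1)c1ccccc1`: > 67000 nM, a limit
Compound 2 `Cc1cc(C)cc(CSc2nc(Cc3c(F)cccc3F)c(C)c(=O)[nH]2)c1`: > 65000 nM, a limit
Compound 3 `Cc1c(Cc2c(F)cccc2F)nc(SCc2cccnc2)[nH]c1=O`: > 70000 nM, a limit

Compound 3 thus has no number, only a limit, and the same holds for the other two. Compound 4 `Cc1c(Cc2c(F)cccc2F)nc(SCC(=O)c2ccccc2)[nH]c1=O` carries benzoyl in place of pyridin-3-yl on a saturated chain carbon bound to a sulfur. Among the compounds with values here, the one measured step at this place, a step that the two limits leave unreadable from compound 2 to compound 3, has no readable size, since both its ends are limits. Compound 1 also carries benzoyl at this place and gives only a limit, > 67000 nM. No step beyond the scatter is therefore expected, and the estimated change is an at least 1.0-fold lower number from compound 3 to compound 4 (0.03 log units; that floor lies within the scatter). In this assay compound 4 is expected at 65000 nM, with an estimated range of 25000 nM to 70000 nM.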

Compound 4, half-maximal cytotoxic concentration: 65000 nM
Compound 4: the middle estimate sits on the measured number at the digits printed; the range from low to high includes it.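

In this assay, within the data shown here, compound 4 gives the first true number at this place, where the earlier compounds gave only limits, and benzoyl in place of 3,5-dimethylphenyl gives a number no higher from compound 2 to compound 4 (the limit leaves the size open). Benzoyl in place of pyridin-3-yl gives an at least 1.0-fold lower number from compound 3 to compound 4 (0.03 log units; that floor lies within the scatter), and methyl in place of hydrogen on an aromatic carbon gives an at least 1.0-fold lower number from compound 1 to compound 4 (0.01 log units; that floor lies within the scatter), so neither change is shown to go beyond the scatter.

Going by these compounds, the true numbers behind the limits of compound 1, compound 2 and compound 3 stay unknown. On these data alone, whether an amine or a carboxylic acid in place of benzoyl would give a lower number in this assay also stays open.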